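The compounds below may be only part of what the source reports. "The series", "measured", "known", "first", "only" and "open" are said of these compounds alone.

Measured compounds:
Compound 1, `Clc1ccc(NCc2cn(-c3ccccc3)nc2-c2ccc(Br)cc2)cc1`: in an ADME assay on MT4 cells (Homo sapiens) for cytotoxicity, read by MTT assay, with a stated time of 96 h (a higher number here means that more compound is tolerated, a lower number that less compound is tolerated), compound 1 gives > 100000 nM; > 100000 nM (2 entries), which is a limit of the assay and not a number.
Compound 2, `Cc1ccc(-c2nn(-c3ccccc3)cc2CNc2ccc(C(F)(F)F)cc2)cc1`: in this assay compound 2 gives > 100000 nM, also a limit of the assay.

Compound 2 thus stands at the limit of this assay rather than at a measured number, with one further entry that likewise carries no single number. Compound 1 sits at the same point, (the limit of > 100000 nM in this assay, at which 1 of the 2 values shown sits), so the two cannot be ordered against each other. Compound 3, `Cc1ccc(-c2nn(-c3ccccc3)cc2CNc2ccc(Cl)cc2)cc1`, has not yet been measured. It differs from compound 2 in one place: chloro in place of trifluoromethyl on an aromatic carbon. Among the measured compounds shown here, no step between measured compounds is available to size this change, and with both measured compounds at the limit, no step beyond the scatter is expected in this assay in either direction. Compound 3 is therefore expected near 100000 nM, within 50000 nM to 200000 nM, most likely again reported only as a limit. The expected step from compound 2 to compound 3 is a number no higher from compound 2 to compound 3 (the limit leaves the size open), none beyond the scatter.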

Compound 3, half-maximal cytotoxic concentration: > 100000 nM
Compound 3: only a limit was reported; the forecaster's own chance of this, stated with the estimate: 85%; the middle value lies on the limit itself.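

No step can be read between compound 2 and compound 3, since both stand at a limit and not at a number: the limit of > 100000 nM in this assay, at which 2 of the 3 values shown sit.

The compounds shown leave open at what concentration any of them would become cytotoxic, and whether chloro and trifluoromethyl differ in this assay at all.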